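The source may hold more compounds than are shown below. What is called first, only, known or untested is meant among the compounds shown, and "the series" means these compounds.

Compound 1 `CC(=O)c1ccccc1OC1CCN(c2ccc(-n3ccnc3)nn2)CC1` was tested in an assay on microsomes from liver for inhibition of acyl-CoA desaturase 1 (Rattus norvegicus) (a lower number here means a stronger inhibitor, a higher number a weaker inhibitor), where compound 1 gives 34 nM. Two other compounds share its core. Compound 3 `Brc1cccc(OC2CCN(c3ccc(-n4ccnc4)nn3)CC2)c1` gives 23 nM in this assay, and compound 2 `c1cc(OC2CCN(c3ccc(-n4ccnc4)nn3)CC2)c2cc[nH]c2c1` gives 162 nM. Among these three numbers compound 1 holds the second highest; its nearest neighbour is compound 3, with a 1.5-fold lower number from compound 1 to compound 3 (0.17 log units; within the scatter), and its furthest is compound 2, with a 4.8-fold higher number from compound 1 to compound 2 (0.68 log units; beyond the scatter). The other two are separated by a 7.0-fold lower number from compound 2 to compound 3 (0.85 log units; beyond the scatter).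

Compound 4 `FC(F)(F)c1ccccc1OC1CCN(c2ccc(-n3ccnc3)nn2)CC1` has not yet been measured. It differs from compound 1 in one place: trifluoromethyl in place of acetyl on an aromatic carbon. The step that bears most directly on this change is the one in which the acetyl was also given up, a 1.5-fold lower number from compound 1 to compound 3 (0.17 log units; within the scatter), which stayed within the scatter. Among the compounds with values here, the only step beyond the scatter, a 4.8-fold higher number from compound 1 to compound 2 (0.68 log units; beyond the scatter), came with the indol-4-yl group, which compound 4 does not carry. Compound 4 is therefore expected to stay close to compound 1, with a 1.1-fold lower number from compound 1 to compound 4 (0.05 log units; within the scatter) in this assay expected to remain within the scatter. The estimate for compound 4 is 30 nM, with an expected range from 12 nM to 80 nM.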

Compound 4, half-maximal inhibitory concentration: 4 nM
The estimate for compound 4 lay 7.5-fold (0.88 log units) above the measured number, and the stated range ends above it.
By their numbers in this assay, from the lowest: compound 4; then compounds 3 and 1 (each within the scatter of the next); then compound 2.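

Compounds 1 to 3 differed by the whole group on the oxygen, so they could not separate the aryl ring from what it carries; here the ring and the place stay the same and only the group on the aromatic carbon changes. In this assay that single change gives an 8.5-fold lower number from compound 1 to compound 4 (0.93 log units; beyond the scatter), which shows that the number responds strongly to the group at this place, ortho to a large group, and that the acetyl can be given up with a clear gain. Trifluoromethyl also carries no hydrogen-bond acceptor, so in this pair the acceptor of the acetyl is not needed for the lower number, and nothing shown here accounts for the size of the step.

The compounds shown hold only two groups at this place, so it remains open whether a methyl, a chlorine, a methoxy or a nitrile on the same aromatic carbon would follow trifluoromethyl or acetyl. Also open, from the compounds shown here alone, is whether trifluoromethyl would give a similar step at another carbon of the ring, or on a core carrying a different group in place of the imidazole.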